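Adding Chloro Where Both Measured Compounds Reach the Limit

The compounds below may be only part of what the source reports. "The series", "measured", "known", "first", "only" and "open" are said of these compounds alone.

Compound 1 `CO[C@@H]1[C@H](N(C)c2ncc(-c3c[nH]c4ccc(Br)cc34)s2)C[C@H]2O[C@]1(C)n1c3ccccc3c3c4c(c5c6ccccc6n2c5c31)C(=O)NC4` and compound 2 `COc1ccc2[nH]cc(-c3cnc(N(C)[C@@H]4C[C@H]5O[C@@](C)([C@@H]4OC)n4c6ccccc6c6c7c(c8c9ccccc9n5c8c64)C(=O)NC7)s3)c2c1` share one large core and differ only at a single aromatic carbon, where methoxy replaces bromo. In a functional assay on K562 cells (Homo sapiens) for antiproliferative activity, read by CellTiter-Glo, with a stated time of 72 h (a higher number here means a weaker inhibitor, a lower number a stronger inhibitor), compound 1 gives > 10000 nM, which is a limit of the assay rather than a number. In this assay compound 2 gives > 10000 nM, again a limit and not a number. The step that the two limits leave unreadable from compound 1 to compound 2 cannot be sized because the limit of > 10000 nM in this assay, at which 2 of the 2 values shown sit, hides whatever difference may exist.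

Compound 3 `COc1ccc2[nH]cc(-c3cnc(N(C)[C@@H]4C[C@H]5O[C@@](C)([C@@H]4OC)n4c6ccccc6c6c7c(c8c9cc(Cl)ccc9n5c8c64)C(=O)NC7)s3)c2c1` differs from compound 2 by chloro in place of hydrogen on an aromatic carbon. Within the data shown here, no measured step involves chloro in place of hydrogen, and the only measured step is unreadable, so nothing here points to a change beyond the scatter in this assay. Compound 3 is therefore expected to give 15000 nM, within 3000 nM to 60000 nM, most likely reported once more as a limit. The step this estimate implies, a step that the limit leaves unreadable from compound 2 to compound 3, is expected to stay within the scatter.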

Compound 3, half-maximal inhibitory concentration: > 10000 nM
Compound 3: no number, only a limit (the forecaster's own chance of this, stated with the estimate: 75%); the middle value lies beyond the limit too.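

No step can be read between compound 2 and compound 3, since each gives only a limit and not a number: the limit of > 10000 nM in this assay, at which 3 of the 3 values shown sit. The compounds shown leave open whether bromo, methoxy or chloro on the shared core makes any difference in this assay.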